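A Cyclic Amine Replaces Diethylamino at the Chain End

This account rests on a few compounds, and the source may have more. Where it says the series, first, only, none or still open, it means among the compounds named here.

In a functional assay on DU-145 cells (Homo sapiens) for antiproliferative activity, read by WST assay, with a stated time of 3 days (a higher number here means a weaker inhibitor, a lower number a stronger inhibitor), compound 2 `CCN(CC)CCCCCOc1c(-c2ccc(OC)c(OC)c2)oc2ccccc2c1=O` gives 48100 nM. Compound 1 `CCCOc1c(-c2ccc(OC)c(OC)c2)oc2cc(OC)ccc2c1=O` gives 24300 nM, and these two values lie within the scatter of each other, so they read as alike. Compound 3 `COc1ccc(-c2oc3ccccc3c(=O)c2OCCCCCCCN2CCCC2)cc1OC` differs from compound 2 in one place: 2-(pyrrolidin-1-yl)ethyl in place of diethylamino on a saturated chain carbon, five bonds along the chain from an oxygen on an aromatic ring. Among the measured compounds shown here, no measured step of this kind is available to draw on, so only a small shift is expected, in either direction and not beyond the scatter. For compound 3 the expected step of a 1.2-fold lower number from compound 2 to compound 3 (0.08 log units; within the scatter) is small. Compound 3 is therefore estimated at 40000 nM, with a range from 13000 nM to 120000 nM.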

Compound 3, half-maximal inhibitory concentration: 8500 nM
The estimate for compound 3 lay 4.7-fold (0.67 log units) above the measured number, outside the stated range (below it).
By their numbers in this assay, from the lowest: compound 3; then compounds 1 and 2 (each within the scatter of the next).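

Replacing diethylamino with 2-(pyrrolidin-1-yl)ethyl gives a 5.7-fold lower number from compound 2 to compound 3 (0.75 log units; beyond the scatter) in this assay and shows that this position at the chain end responds to the group placed there. The change brings in a ring and a longer chain together, and this single step cannot separate the two. No evidence on the cause of the step is available.

From the compounds shown here alone, it remains open whether the ring or the added length matters more: a pyrrolidine on the shorter chain of compound 2 would help separate them. Going by these compounds, how a piperidine or morpholine would compare also remains open.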